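Adding a Chloro to the Fluorophenyl of Compound 3

This account rests on a few compounds, and the source may have more. Where it says the series, first, only, none or still open, it means among the compounds named here.

Three compounds share one core and differ only in the group on one aromatic carbon. Compound 1 `Cc1nnc(COc2cnn(C(C)(C)C)c(=O)c2Cl)o1` carries a methyl there; in a functional assay on the whole organism for inhibition, with Mythimna separata as the target, with a stated time of 5 days (on this read-out lower numbers stand for an effect already at smaller amounts and higher numbers for an effect only at larger amounts of compound), compound 1 reaches only a limit, > 300 ug/mL. Compound 2 `COc1ccc(-c2nnc(COc3cnn(C(C)(C)C)c(=O)c3Cl)o2)cc1` gives 17.7 ug/mL in this assay, and compound 3 `CC(C)(C)n1ncc(OCc2nnc(-c3ccccc3F)o2)c(Cl)c1=O` gives 16.8 ug/mL. Swapping the methyl for an aryl group brought an at least 16-fold lower number from compound 1 to compound 2 (1.22 log units; beyond the scatter) and an at least 17-fold lower number from compound 1 to compound 3 (1.25 log units; beyond the scatter). Between the two aryl compounds the difference is a 1.1-fold lower number from compound 2 to compound 3 (0.02 log units; within the scatter), so compound 3 sits at the low end of the numbers shown, alongside compound 2, and the two cannot be told apart.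

Compound 4 `CC(C)(C)n1ncc(OCc2nnc(-c3ccc(Cl)cc3F)o2)c(Cl)c1=O` differs from compound 3 by chloro in place of hydrogen on an aromatic carbon. For the measured compounds named here, no measured step adds a group to the aryl ring; the only step that changes the aryl, a 1.1-fold lower number from compound 2 to compound 3 (0.02 log units; within the scatter), is within the scatter. On that basis the expected step is a 1.1-fold lower number from compound 3 to compound 4 (0.05 log units; within the scatter), none beyond the scatter. Compound 4 is therefore estimated at 15 ug/mL, within a range of 5 ug/mL to 45 ug/mL.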

Compound 4, half-maximal effective concentration: 10.4 ug/mL
Estimate against measurement, compound 4: 1.4-fold (0.16 log units) above; the range from low to high includes it.
By their numbers in this assay, from the lowest: compounds 4, 3 and 2 (each within the scatter of the next). At a limit, above all of these: compound 1.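

For the compounds shown here, the chloro is the first group added to the aryl ring itself, para to a large group and meta to the fluoro group, and in this assay it gives a 1.6-fold lower number from compound 3 to compound 4 (0.21 log units; within the scatter), so compounds 3 and 4 cannot be told apart and the position accepts this extra atom without a loss that can be read. Against the 4-methoxyphenyl group the picture is the same, with a 1.7-fold lower number from compound 2 to compound 4 (0.23 log units; within the scatter), so the three aryl compounds form one group. The gap to the methyl compound remains large, with an at least 28-fold lower number from compound 1 to compound 4 (1.46 log units; beyond the scatter), but its size is only a bound, since the value of compound 1 is a limit and not a number: the limit of > 300 ug/mL in this assay, at which 1 of the 4 values shown sits.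

From the compounds shown here alone, whether this position would accept an amine, a carboxylic acid or a longer chain stays open. So does whether the chloro would behave the same on a ring without the fluoro group.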